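The compounds below may be only part of what the source reports. "The series", "measured", "known", "first", "only" and "open" are said of these compounds alone.

Series values in a functional assay on CHO-K1 cells for antagonist activity at transient receptor potential cation channel subfamily V member 1 (Homo sapiens), read by FLIPR; a lower number here means a stronger inhibitor, a higher number a weaker inhibitor:

compound 1 `CC(C(=O)NCc1ccc(C(F)(F)F)nc1N1CCN(C)CC1)c1ccc(NS(C)(=O)=O)c(F)c1`: 146 nM
compound 2 `CC(C(=O)NCc1ccc(C(F)(F)F)nc1N1CCN(C2CCCCC2)CC1)c1ccc(NS(C)(=O)=O)c(F)c1`: 21.6 nM
compound 3 `CC(C(=O)NCc1ccc(C(F)(F)F)nc1N1CCN(c2ccc(C(F)(F)F)cc2)CC1)c1ccc(NS(C)(=O)=O)c(F)c1`: 2.3 nM

Compound 3 gives the lowest number of the three; its nearest neighbour is a 9.4-fold lower number from compound 2 to compound 3 (0.97 log units; beyond the scatter), and the widest gap is a 63-fold lower number from compound 1 to compound 3 (1.80 log units; beyond the scatter). Compound 4 `CC(C(=O)NCc1ccc(C(F)(F)F)nc1N1CCN(c2ncccc2C(F)(F)F)CC1)c1ccc(NS(C)(=O)=O)c(F)c1` differs from compound 3 by 3-(trifluoromethyl)pyridin-2-yl in place of 4-(trifluoromethyl)phenyl on an amine nitrogen in a ring. Among the measured compounds shown here, no measured step swaps one aromatic group for another on this ring nitrogen: the two steps that bear on it, a 63-fold lower number from compound 1 to compound 3 (1.80 log units; beyond the scatter) and a 9.4-fold lower number from compound 2 to compound 3 (0.97 log units; beyond the scatter), both exchange an alkyl group for the same aromatic group, so they mark the aromatic substituent as the favourable state rather than predicting this exchange. Compound 4 is therefore expected to remain near compound 3, with a 1.7-fold higher number from compound 3 to compound 4 (0.24 log units; within the scatter), and the estimate is 4 nM within 1.5 nM to 12 nM.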

Compound 4, inhibition constant: 2.8 nM
For compound 4 the middle estimate is 1.4-fold (0.15 log units) above the measured one; the measured number falls inside the stated range.
By their numbers in this assay, from the lowest: compounds 3 and 4 (each within the scatter of the next); then compound 2; then compound 1.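

In this assay, exchanging one aromatic group for another on this ring nitrogen gives a step within the scatter (a 1.2-fold higher number from compound 3 to compound 4 (0.09 log units; within the scatter)), so 3-(trifluoromethyl)pyridin-2-yl, with its added hydrogen-bond acceptor, is tolerated here. The gain over alkyl groups extends to this second aromatic group (a 7.7-fold lower number from compound 2 to compound 4 (0.89 log units; beyond the scatter); a 52-fold lower number from compound 1 to compound 4 (1.72 log units; beyond the scatter)). No evidence on the reason for this outcome is available.

The exchange alters both the ring atom and the name-given location of trifluoromethyl, and these two changes remain unseparated. Going by these compounds, whether trifluoromethyl itself is needed remains open, and a chlorine or a nitrile in its place would address that.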